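This account rests on a few compounds, and the source may have more. Where it says the series, first, only, none or still open, it means among the compounds named here.

In a functional assay on VCaP cells (Homo sapiens) for antiproliferative activity, read by CCK-8 assay, with a stated time of 6 days (a lower number here means a stronger inhibitor, a higher number a weaker inhibitor), compound 1 (`C[C@@H](Cn1ccc(-c2ccc(C#N)c(Cl)c2)n1)NS(=O)(=O)c1cccnc1`) gives 2450 nM and compound 2 (`C[C@@H](Cn1ccc(-c2ccc(C#N)c(Cl)c2)n1)NS(=O)(=O)c1cn(C)cn1`) gives 13600 nM. Among the measured compounds shown here, the only measured step is a 5.6-fold higher number from compound 1 to compound 2 (0.74 log units; beyond the scatter), with 1-methyl-1H-imidazol-4-yl in place of pyridin-3-yl on a sulfonyl sulfur. Compound 3 (`C[C@@H](Cn1ccc(-c2ccc(C#N)c(Cl)c2)n1)Nc1ccccn1`) offers no number as a starting point: its result reads "not determined" (no result reported). Compound 4 (`Cc1ccnc(N[C@@H](C)Cn2ccc(-c3ccc(C#N)c(Cl)c3)n2)n1`) differs from it as follows: 4-methylpyrimidin-2-yl in place of pyridin-2-yl on an amine nitrogen. For the measured compounds named here, the step of a 5.6-fold higher number from compound 1 to compound 2 (0.74 log units; beyond the scatter) concerns a sulfonyl sulfur, not an amine nitrogen, so it suggests only that a ring exchange may bring a modest change of that order. No direction can be expected without a value for compound 3. Compound 4 is expected near 4000 nM, with an estimated range of 800 nM to 20000 nM.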

Compound 4, half-maximal inhibitory concentration: 850 nM
For compound 4 the middle estimate is 4.7-fold (0.67 log units) above the measured one, and the stated range covers the measured number.
By their numbers in this assay, from the lowest: compound 4; then compound 1; then compound 2.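

On the amine nitrogen, the sulfonyl link is not required in this assay: 4-methylpyrimidin-2-yl in place of (pyridin-3-yl)sulfonyl gives a 2.9-fold lower number from compound 1 to compound 4 (0.46 log units; beyond the scatter), and in place of (1-methyl-1H-imidazol-4-yl)sulfonyl gives a 16-fold lower number from compound 2 to compound 4 (1.20 log units; beyond the scatter), so compound 4 has the lowest number of the three measured compounds. The step from compound 3 cannot be read, as compound 3 has no result. No measurement shown accounts for these steps. On these data alone, what the methyl group of the 4-methylpyrimidin-2-yl contributes remains open, as does how an unsubstituted pyrimidin-2-yl or an acetyl group on this amine nitrogen would compare.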